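Solubility of a Bicyclic Amine Variant of Compound 1

The source may hold more compounds than are shown below. What is called first, only, known or untested is meant among the compounds shown, and "the series" means these compounds.

Measured compounds:
compound 1, `COc1ccc2[nH]c(C(=O)N3CC(=O)N(Cc4ccccc4)[C@@H](CN4CCC(C)CC4)C3)cc2c1`: 93100 nM
compound 2, `COc1ccc2[nH]c(C(=O)N3CC(=O)N(Cc4cc5ccccc5[nH]4)[C@@H](Cc4ccccc4)C3)cc2c1`: 11000 nM
compound 3, `COc1ccc2[nH]c(C(=O)N3CC(=O)N(Cc4c[nH]c5ccccc45)[C@@H](Cc4ccccc4)C3)cc2c1`: 10300 nM

In a physicochemical assay for solubility, read by spectrophotometry, in phosphate buffer, with a stated time of 2 h, at pH 7.4 (a lower number here means a less soluble compound, a higher number a more soluble compound), compound 1 gives 93100 nM and stands highest of the three measured compounds. Compound 2 gives 11000 nM and compound 3 gives 10300 nM; both lie far below compound 1, beyond the scatter. For the measured compounds named here, the only measured step between neighbours is a 1.1-fold lower number from compound 2 to compound 3 (0.03 log units; within the scatter), which concerns the group on the amide-type nitrogen and does not touch the part of the molecule changed here.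

Compound 4, `COc1ccc2[nH]c(C(=O)N3CC(=O)N(Cc4ccccc4)[C@@H](CN4CC5CCCC5C4)C3)cc2c1`, differs from compound 1 in one place: a group of 8 heavy atoms (7 carbon, 1 nitrogen; one five-membered non-aromatic ring of carbon only, one five-membered non-aromatic ring with 1 hetero atom) in place of a group of 7 heavy atoms (6 carbon, 1 nitrogen; one six-membered non-aromatic ring with 1 hetero atom), on a saturated chain carbon bound to a saturated ring carbon. Going by the values given here, no measured pair shows what such an exchange does in this assay, so the expectation rests on compound 1 alone. Because compound 1 gives 93100 nM and the change adds little, a step no larger than the scatter is expected, a 1.3-fold lower number from compound 1 to compound 4 (0.12 log units; within the scatter). Compound 4 is therefore estimated at 70000 nM, with a range from 30000 nM to 160000 nM.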

Compound 4, solubility: 20700 nM
For compound 4 the middle estimate is 3.4-fold (0.53 log units) above the measured one; the whole stated range lies above it.
By their numbers in this assay, from the lowest: compounds 3, 2 and 4 (each within the scatter of the next); then compound 1.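

At this position, on a saturated chain carbon bound to a saturated ring carbon, the choice of amine proves to matter: in this assay, the group with two five-membered rings in place of 4-methylpiperidin-1-yl gives a 4.5-fold lower number from compound 1 to compound 4 (0.65 log units; beyond the scatter) for this exchange. The two groups have the same counts of hydrogen-bond donors and acceptors and the same net charge, so the step arises with those counts unchanged. The set offers no explanation for the step.

Going by these compounds, it remains open whether the step follows from the fused ring system or from the loss of the methyl group, which piperidin-1-yl, pyrrolidin-1-yl or morpholin-4-yl at the same place could help separate. Also open, on these data alone, is whether the exchange gives a similar step with a 1H-indol-2-yl group in place of the phenyl on the benzyl group.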